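Aryl variation on the urea nitrogen of the shared core

A few compounds are considered here, and "the series" means these few. Any claim that something is new, unique, unknown or untested is made for them only; others in the source may bear on it.

Going by the values given here, in a functional assay on A375P cells (Homo sapiens) for antiproliferative activity (a higher number here means a weaker inhibitor, a lower number a stronger inhibitor), compound 2 `Cc1ccc(NC(=O)Nc2cc(Cl)cc(Cl)c2)cc1NC(=O)c1ccccc1` is the only member that returns a number, 259 nM. Compound 1 `Cc1ccc(NC(=O)Nc2ccccc2Cl)cc1NC(=O)c1ccccc1` returns only a limit of the assay, > 30000 nM. Among the compounds with values here, the single measured step, an at least 110-fold lower number from compound 1 to compound 2 (2.06 log units; beyond the scatter), is known only as a lower bound because compound 1 sits at the limit of > 30000 nM in this assay, at which 1 of the 2 values shown sits, yet it shows that the aryl group on the amide-type nitrogen moves the read-out by a large amount.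

Compound 3 `Cc1ccc(NC(=O)Nc2ccc(C)c(NC(=O)c3ccccc3)c2)cc1C` differs from compound 2 in the same place: 3,4-dimethylphenyl in place of 3,5-dichlorophenyl on an amide-type nitrogen. The step from compound 1 to compound 2 is the only one that bears on this exchange; it tells that the aryl group at this position matters strongly, but not whether dimethyl substitution acts in the same sense as dichloro substitution. Within the data shown here, with compound 2 holding the only numerical value and this position having so far produced a large movement, compound 3 is expected to be a weaker inhibitor, the estimated step being a 5.8-fold higher number from compound 2 to compound 3 (0.76 log units; beyond the scatter). The expected value for compound 3 is 1500 nM, in the range from 300 nM to 8000 nM.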

Compound 3, half-maximal inhibitory concentration: > 30000 nM
Compound 3: no number, only a limit; the forecaster's own chance of this, stated with the estimate: 15%; at least 20-fold (1.30 log units) between middle value and limit.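

In this assay, a second exchange on the amide-type nitrogen gives a large movement, an at least 110-fold higher number from compound 2 to compound 3 (2.06 log units; beyond the scatter), so the sensitivity of this position does not rest on the 2-chlorophenyl comparison alone. Compound 3 returns a limit of the assay, > 30000 nM, and not a number, so 3,5-dichlorophenyl remains the only one of the three aryl groups shown with a measured value, while 3,4-dimethylphenyl joins 2-chlorophenyl at the limit. The steps between compound 1 and compound 3 cannot be read, because both compounds sit at the same limit: the limit of > 30000 nM in this assay, at which 2 of the 3 values shown sit.

The change from 3,5-dichlorophenyl to 3,4-dimethylphenyl alters both the substituent atoms and their placing on the ring, and the compounds shown do not separate these two changes, which 3,4-dichlorophenyl or 3,5-dimethylphenyl would begin to do. Also open, from the compounds shown here alone, is how an unsubstituted phenyl or a phenyl carrying two trifluoromethyl groups would read on this nitrogen, and so whether the number seen for compound 2 is specific to chlorine.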